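The source may hold more compounds than are shown below. What is called first, only, known or untested is meant among the compounds shown, and "the series" means these compounds.

Values in a functional assay on the whole organism for agonist activity, with Mus musculus as the target; a lower number here means that less compound is needed, a higher number that more compound is needed for the effect:
- Compound 1 `CC(C#CCn1ccnc1)N1CCCC1=O`: > 100 mg/kg (a limit)
- Compound 2 `Cc1cncn1CC#CC(C)N1CCCC1=O`: > 100 mg/kg (a limit)
- Compound 3 `CC(C#CCN(C)C)N1CCCC1=O`: not yet measured

In this assay compound 1 stands only at a limit, > 100 mg/kg, so it has no number to start from. Compound 2 offers no better reference, as the evidence shows the same reading for both: the limit of > 100 mg/kg in this assay, at which 2 of the 2 values shown sit.

The change under consideration is dimethylamino in place of 1H-imidazol-1-yl on a saturated chain carbon bound to a triple-bonded carbon. Going by the values given here, the only measured step, a step that the two limits leave unreadable from compound 1 to compound 2, is methyl in place of hydrogen on an aromatic carbon. It has no readable size and keeps the 1H-imidazol-1-yl group, so it gives no size to carry over to this change.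

The limit of compound 1 leaves a readable result possible only on the side of less compound needed in this assay, although another limit remains possible. The expected at least 12-fold lower number from compound 1 to compound 3 (1.09 log units; beyond the scatter) is therefore a loose estimate. For compound 3 the estimated value is 8 mg/kg, with an expected range of 1 mg/kg to 60 mg/kg.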

Compound 3, dose for half-maximal effect: 6.6 mg/kg
Beside the measured number, compound 3's estimate is 1.2-fold (0.08 log units) above it; the measured number falls inside the stated range.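

In this assay, the series now has its first readable step at this place, on a saturated chain carbon bound to a triple-bonded carbon: dimethylamino in place of 1H-imidazol-1-yl gives an at least 15-fold lower number from compound 1 to compound 3 (1.18 log units; beyond the scatter). As far as these compounds go, the size of this step is only a lower bound, as its starting point is a limit and not a number, so the full extent of the change remains unknown. Among the compounds shown, compound 3 alone has a measured number and alone lacks the five-membered aromatic ring at this place, while the two compounds that keep the ring stay at the limit: the limit of > 100 mg/kg in this assay, at which 2 of the 3 values shown sit.

The step from compound 1 to compound 2, with methyl in place of hydrogen on an aromatic carbon, cannot be read, so the compounds shown say nothing about the effect of substitution on that ring. From the compounds shown here alone, it also remains open whether this gain is specific to dimethylamino or extends to other open-chain amines such as diethylamino, and whether a longer chain carrying the amine would keep it.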